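Iodo for ethynyl on a methoxy core of uncertain footing

The compounds below may be only part of what the source reports. "The series", "measured", "known", "first", "only" and "open" are said of these compounds alone.

Measured compounds:
compound 1 `C#Cc1cn([C@@H]2O[C@H](CO)[C@@H](O)[C@H]2O)c2ncnc(NC)c12` gives > 20000 nM in a functional assay on K562 cells (Homo sapiens), read by MTT assay, with a stated time of 72 h; on this read-out lower numbers stand for stronger inhibition and higher numbers for weaker inhibition
compound 2 `CNc1ncnc2c1c(I)cn2[C@@H]1O[C@H](CO)[C@@H](O)[C@H]1O` gives > 100000 nM
compound 3 `C#Cc1cn([C@@H]2O[C@H](CO)[C@@H](O)[C@H]2O)c2ncnc(OC)c12` gives 300 nM

The value of compound 1 in this assay is a limit, not a number. The value of compound 2 is likewise a limit. Compound 3 is the only one of the three with a real number. The pair compound 1 and compound 2 differ by iodo in place of ethynyl on an aromatic carbon, and the step between them, a step that the two limits leave unreadable from compound 1 to compound 2, cannot be read because the limit of > 20000 nM in this assay, at which 1 of the 3 values shown sits, and the limit of > 100000 nM in this assay, at which 1 of the 3 values shown sits, bound both ends. The two cores differ by methoxy in place of methylamino on an aromatic carbon, and that step, an at least 66-fold lower number from compound 1 to compound 3 (1.82 log units; beyond the scatter), is large and beyond the scatter.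

Compound 4 `COc1ncnc2c1c(I)cn2[C@@H]1O[C@H](CO)[C@@H](O)[C@H]1O` is not yet measured. It differs from compound 3 by iodo in place of ethynyl on an aromatic carbon, the same change that leads from compound 1 to compound 2, and the place is described in the same words for both pairs. Going by the values given here, the only earlier example of this change gives no readable size, so the expectation for compound 4 rests on compound 3 alone and on the absence of any readable precedent. Compound 4 is therefore expected to sit at 3000 nM in this assay, within 300 nM to 30000 nM, and the estimated step of a 10-fold higher number from compound 3 to compound 4 (1.00 log units; beyond the scatter) is tentative.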

Compound 4, half-maximal inhibitory concentration: > 20000 nM
Compound 4 ended at the assay's limit (the forecaster's own chance of this, stated with the estimate: 25%); middle value at least 6.6-fold (0.82 log units) from the limit.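

In this assay, on the core of compound 3, iodo in place of ethynyl on an aromatic carbon gives an at least 66-fold higher number from compound 3 to compound 4 (1.82 log units; beyond the scatter), a large step beyond the scatter, and it shows that on this core ethynyl cannot be swapped for iodo without a heavy loss of inhibition. From the compounds shown here alone, the value of compound 4 is a limit and not a number, so the printed size is only a floor and the true size of the step stays unknown: the limit of > 20000 nM in this assay, at which 2 of the 4 values shown sit. The same change on the core of compound 1 and the change from methylamino to methoxy between compound 2 and compound 4 cannot be read, since both ends of each pair are limits, so this single readable case does not show whether the size of the step carries from one core to the other.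

The compounds shown leave open whether a nitrile, a vinyl or a chloro on that same aromatic carbon would keep the methoxy core near compound 3, which gives 300 nM, or would fall away as iodo does. They also leave open whether an ethoxy or a dimethylamino in place of methoxy would hold up beside ethynyl.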